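Nitro in place of methyl: expected cytotoxicity of compound 4

This account rests on a few compounds, and the source may have more. Where it says the series, first, only, none or still open, it means among the compounds named here.

Measured in an ADME assay on MT4 cells (Homo sapiens) for cytotoxicity, read by MTT assay, with a stated time of 96 h (a higher number here means that more compound is tolerated, a lower number that less compound is tolerated), so far
compound 1 `Cc1ccc(/N=N/c2ccc(NCCCN(C)C)cc2)cc1` gives 17000 nM
compound 2 `CN(C)CCCN(/N=N/c1cc(F)ccc1F)c1ccccc1` gives 13000 nM
compound 3 `CN(C)CCCN(/N=N/c1cccc([N+](=O)[O-])c1)c1ccccc1` gives 14000 nM

Compound 1 stands level with the other two, as all three values lie within the scatter of each other. Still unmeasured, compound 4 `CN(C)CCCNc1ccc(/N=N/c2ccc([N+](=O)[O-])cc2)cc1` keeps the core of compound 1 and has nitro in place of methyl on an aromatic carbon, para to a large group nitro in place of methyl on an aromatic carbon in one place only. Among the compounds with values here, no two measured compounds differ in one place, so no direct step is available. Compound 3 also carries a nitro group, on another core, and gives 14000 nM on the same level as compound 1. No step beyond the scatter is therefore expected in this assay. The estimated move is a 1.4-fold lower number from compound 1 to compound 4 (0.15 log units; within the scatter) and is expected to stay inside the scatter. For compound 4 the estimated value is 12000 nM with an expected range of 5000 nM to 25000 nM on measurement.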

Compound 4, half-maximal cytotoxic concentration: 19000 nM
For compound 4 the middle estimate is 1.6-fold (0.20 log units) below the measured one; the measured number falls inside the stated range.
By their numbers in this assay, from the lowest: compounds 2, 3, 1 and 4 (each within the scatter of the next).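

Within the data shown here, this is the only single-place change so far: in this assay, nitro in place of methyl on an aromatic carbon, para to a large group, gives a 1.1-fold higher number from compound 1 to compound 4 (0.05 log units; within the scatter). On the core of compound 1, this position therefore does not separate the two groups in cytotoxicity. No measurement bearing on a cause is at hand. Going by these compounds, whether an amine or a carboxylic acid on this carbon would stay level with methyl and nitro remains open. On these data alone, the effect of a longer chain in place of methyl is also open.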